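From Methyl to Nitro on the Same Aromatic Carbon

The compounds below may be only part of what the source reports. "The series", "measured", "known", "first", "only" and "open" are said of these compounds alone.

Measured compounds:
Compound 1, `Cc1ccccc1C1(CNC(=O)Nc2c(C(C)C)cccc2C(C)C)CCCC1`: 17 nM
Compound 2, `Cc1cccc(C2(CNC(=O)Nc3c(C(C)C)cccc3C(C)C)CCCC2)c1`: 15 nM
Compound 3, `CC(C)c1cccc(C(C)C)c1NC(=O)NCC1(c2cccc(OCc3ccccc3)c2)CCCC1`: 30 nM

All three share the same urea core and differ only in the group attached to one aromatic ring. In an assay on microsomes for inhibition of acyl-CoA:cholesterol acyltransferase (Oryctolagus cuniculus) (a higher number here means a weaker inhibitor, a lower number a stronger inhibitor), compound 2 gives the lowest number of the three, yet both of its neighbours sit within the usual scatter: a 1.1-fold lower number from compound 1 to compound 2 (0.05 log units; within the scatter) and a 2.0-fold higher number from compound 2 to compound 3 (0.30 log units; within the scatter). Nothing in these numbers therefore separates compound 2 from compound 1 or compound 3.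

The next compound, compound 4, `CC(C)c1cccc(C(C)C)c1NC(=O)NCC1(c2cccc([N+](=O)[O-])c2)CCCC1`, is made from compound 2 by a single replacement: nitro in place of methyl on an aromatic carbon. Among the compounds with values here, the one measured step that bears on this change is the one from compound 2 to compound 3, where a methyl at the same aromatic carbon was exchanged for a much larger benzyloxy group without moving the number beyond the scatter. Within the data shown here, no nitro-bearing compound has been measured, so the exchange of methyl for nitro is untested here. On the evidence of the benzyloxy step, a step of similar size is expected, that is a 1.3-fold higher number from compound 2 to compound 4 (0.12 log units; within the scatter), with no change beyond the scatter. Compound 4 is therefore estimated at 20 nM, ranging from 8 nM to 50 nM.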

Compound 4, half-maximal inhibitory concentration: 51 nM
Compound 4: middle estimate off by 2.6-fold (0.41 log units), on the low side; the whole stated range lies below it.
By their numbers in this assay, from the lowest: compounds 2, 1, 3 and 4 (each within the scatter of the next, the first and the last beyond it).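

In this assay, within the data shown here, this aromatic carbon had so far taken methyl and benzyloxy without a step beyond the scatter, but nitro gives the first modest step that passes it there, a 3.4-fold higher number from compound 2 to compound 4 (0.53 log units; beyond the scatter), and the comparison with the 2-methylphenyl compound agrees, with a 3.0-fold higher number from compound 1 to compound 4 (0.48 log units; beyond the scatter). The number does not simply follow the size of the group, since the much larger benzyloxy stays within the scatter of methyl while nitro does not; the separation is thin, however, as nitro and benzyloxy themselves are not told apart by a 1.7-fold higher number from compound 3 to compound 4 (0.23 log units; within the scatter). Nothing available here gives a measured reason for the step from methyl to nitro.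

The compounds shown leave open whether an amine, a carboxylic acid or a nitrile on this same aromatic carbon would stay with methyl or move the number as nitro does. Also open, as far as these compounds go, is whether the exchange of methyl for nitro would give a step of this size on a different core.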